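Swapping benzyloxy for dimethylamino on a carbonyl carbon

The source may report more compounds than this note shows. Statements on the series, on what has been measured and on what is new or still open speak of the compounds shown alone.

In an ADME assay on HeLa cells (Homo sapiens) for cytotoxicity, read by MTT assay, with a stated time of 2 days (on this read-out higher numbers stand for lower toxicity in this test and lower numbers for higher toxicity in this test), compound 1 (`CNC(=O)c1cc(Oc2ccc3c(C)c(C(=O)OC(C)C)sc3c2)ccn1`) gives 9600 nM and compound 2 (`CNC(=O)c1cc(Oc2ccc3c(C)c(C(=O)OCc4ccccc4)sc3c2)ccn1`) gives 18100 nM, two values within the scatter of each other. Compound 3 (`CNC(=O)c1cc(Oc2ccc3c(C)c(C(=O)N(C)C)sc3c2)ccn1`) carries dimethylamino in place of benzyloxy on a carbonyl carbon. For the measured compounds named here, the one measured step, a 1.9-fold higher number from compound 1 to compound 2 (0.28 log units; within the scatter), also changes a group at that carbonyl, but no measured compound carries dimethylamino there, so it is only a loose guide. No change beyond the scatter is therefore expected in this assay. For compound 3 the estimate is 15000 nM, with a range from 5000 nM to 45000 nM. The expected step is a 1.2-fold lower number from compound 2 to compound 3 (0.08 log units; within the scatter).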

Compound 3, half-maximal cytotoxic concentration: 44400 nM
Beside the measured number, compound 3's estimate is 3.0-fold (0.47 log units) below it; the measured number falls inside the stated range.
By their numbers in this assay, from the lowest: compounds 1 and 2 (each within the scatter of the next); then compound 3.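

In this assay, the isopropyl and benzyl esters had stayed within the scatter of each other, so this carbonyl carbon had shown no clear response to a change of group. With benzyloxycarbonyl changed to dimethylcarbamoyl, a change beyond the scatter appears: a 2.5-fold higher number from compound 2 to compound 3 (0.39 log units; beyond the scatter), and a 4.6-fold higher number from compound 1 to compound 3 (0.67 log units; beyond the scatter), both modest and both towards lower toxicity in this test. Nothing available explains this shift.

On these data alone, only one amide stands here, so it remains open whether a smaller amine on this carbonyl carbon, such as methylamino, or a carboxylic acid would follow compound 3 or the esters.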